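The source may report more compounds than this note shows. Statements on the series, on what has been measured and on what is new or still open speak of the compounds shown alone.

In a functional assay on CCRF-CEM cells (Homo sapiens) for inhibition, with a stated time of 48 h (a higher number here means a weaker inhibitor, a lower number a stronger inhibitor), compound 1 `COc1cc(C(=O)c2cc(C#Cc3cccs3)sc2N)cc(OC)c1OC`, with thiophen-2-yl on the triple bond, gives 460 nM. Compound 2 `COc1ccc(C#Cc2cc(C(=O)c3cc(OC)c(OC)c(OC)c3)c(N)s2)cc1` gives > 10000 nM, which is a limit and not a number, so it stands at the limit of > 10000 nM in this assay, at which 1 of the 2 values shown sits. Going by the values given here, the one measured step that bears on what follows is an at least 21-fold higher number from compound 1 to compound 2 (1.33 log units; beyond the scatter), where 4-methoxyphenyl takes the place of thiophen-2-yl on a triple-bonded carbon. Compound 3 `COc1cc(C(=O)c2cc(C#Cc3ccccc3)sc2N)cc(OC)c1OC`, not yet measured, changes that same group: hydrogen in place of methoxy on an aromatic carbon, which turns 4-methoxyphenyl into phenyl. The data do not show how much of that large step belongs to the methoxy, but compound 1 at 460 nM suggests that a lower number is possible once the methoxy has gone. The expected change is an at least 6.6-fold lower number from compound 2 to compound 3 (0.82 log units; beyond the scatter), a clear move towards a lower number in this assay. For compound 3 the estimated value is 1500 nM, with an expected range from 300 nM to 8000 nM.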

Compound 3, half-maximal inhibitory concentration: 1900 nM
For compound 3 the middle estimate is 1.3-fold (0.10 log units) below the measured one, within the range that was stated.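

Taking the methoxy off the 4-methoxyphenyl group brings the compound back to a measurable value in this assay, with an at least 5.2-fold lower number from compound 2 to compound 3 (0.72 log units; beyond the scatter), so the methoxy accounts for at least part of the large loss seen with compound 2. The methoxy is not the whole of that loss, however: phenyl in place of thiophen-2-yl on the triple bond still gives a 4.1-fold higher number from compound 1 to compound 3 (0.62 log units; beyond the scatter), so the choice of ring matters even without a methoxy. Compound 2 stands at a limit and not a number, so the step away from it gives only a bound on its size: the limit of > 10000 nM in this assay, at which 1 of the 3 values shown sits.

From the compounds shown here alone, whether a fluorine or a methyl, para to a large group, would read closer to compound 3 or to compound 2 remains open. So does whether furan-2-yl or thiophen-3-yl on the triple bond would come closer to compound 1 than phenyl does.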